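Compound 3 to compound 4: exchanging the aryl group

A few compounds are considered here, and "the series" means these few. Any claim that something is new, unique, unknown or untested is made for them only; others in the source may bear on it.

compound 1 `COCC#Cc1cc(C(O)(C(F)(F)F)C(F)(F)F)cnc1N1CCN(S(=O)(=O)c2ccc(N)nc2)CC1` gives 399 mL.min-1.g-1 and no more
compound 2 `CS(=O)(=O)Nc1cccc(-c2cc(C(O)(C(F)(F)F)C(F)(F)F)cnc2N2CCN(S(=O)(=O)c3ccc(N)nc3)CC2)c1` gives 81 mL.min-1.g-1 and no more
compound 3 `NC(=O)c1cccc(-c2cc(C(O)(C(F)(F)F)C(F)(F)F)cnc2N2CCN(S(=O)(=O)c3ccc(N)nc3)CC2)c1` gives 63 mL.min-1.g-1 and no more

In an ADME assay (liver) for metabolic stability, with Liver microsome (Rattus norvegicus) as the target, using microsomes and NADPH, with a stated time of 30 min, tested at 1 uM (a lower number here means slower removal, a higher number faster removal of the compound), compound 3 sits at the low end of the three, level with its nearest neighbour within the scatter (a 1.3-fold lower number from compound 2 to compound 3 (0.11 log units; within the scatter)), and clear of the alkyne (a 6.3-fold lower number from compound 1 to compound 3 (0.80 log units; beyond the scatter)). Compound 4 `CS(=O)(=O)c1ccc(-c2cc(C(O)(C(F)(F)F)C(F)(F)F)cnc2N2CCN(S(=O)(=O)c3ccc(N)nc3)CC2)cc1` is the next case, with 4-(methylsulfonyl)phenyl in place of 3-carbamoylphenyl (4-(methylsulfonyl)phenyl in place of 3-carbamoylphenyl on an aromatic carbon). The aryl-for-alkyne steps, including a 4.9-fold lower number from compound 1 to compound 2 (0.69 log units; beyond the scatter), do not apply, since the phenyl stays. The exchange of carbamoyl for methanesulfonamido is the closest guide, and it was small. For the measured compounds named here, no measured compound carries the 4-(methylsulfonyl)phenyl group. Expected is a 1.1-fold higher number from compound 3 to compound 4 (0.05 log units; within the scatter) and thus nothing beyond the scatter. Compound 4 is estimated at 70 mL.min-1.g-1 (expected range 32 mL.min-1.g-1 to 150 mL.min-1.g-1).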

Compound 4, intrinsic clearance in microsomes: 103 mL.min-1.g-1
Compound 4: middle estimate off by 1.5-fold (0.17 log units), on the low side; low and high end bracket the measured number.
By their numbers in this assay, from the lowest: compounds 3, 2 and 4 (each within the scatter of the next); then compound 1.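

In this assay, replacing 3-carbamoylphenyl with 4-(methylsulfonyl)phenyl removes the hydrogen-bond donor of the leaving group without a change beyond the scatter (a 1.6-fold higher number from compound 3 to compound 4 (0.21 log units; within the scatter)), and the same holds against the sulfonamide (a 1.3-fold higher number from compound 2 to compound 4 (0.10 log units; within the scatter)). The drop from the alkyne therefore extends to a third substituted phenyl (a 3.9-fold lower number from compound 1 to compound 4 (0.59 log units; beyond the scatter)). Nothing available explains these numbers. On these data alone, whether an unsubstituted phenyl keeps this level remains open. So does whether an amine or a carboxylic acid on the phenyl moves the number beyond the scatter.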